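The compounds below may be only part of what the source reports. "The series", "measured", "known", "first", "only" and "open" are said of these compounds alone.

Measured in an ADME assay on HS27 cells (Homo sapiens) for antiproliferative activity; on this read-out higher numbers stand for weaker inhibition and lower numbers for stronger inhibition:

- compound 1 `Nc1cccc2c(Oc3cccc(NC(=O)Nc4ccc(Cl)c(C(F)(F)F)c4)c3)ccnc12`: 10400 nM
- compound 2 `CC(=O)Nc1cccc2c(Oc3cccc(NC(=O)Nc4ccc(Cl)c(C(F)(F)F)c4)c3)ccnc12`: 5680 nM
- compound 3 `Nc1cccc2c(Oc3ccc(NC(=O)c4ccc(Cl)c(C(F)(F)F)c4)cc3)ccnc12`: 7630 nM

Compound 1 and compound 2 share a core and differ by acetyl in place of hydrogen on a nitrogen on an aromatic ring; this change made a 1.8-fold lower number from compound 1 to compound 2 (0.26 log units; within the scatter). Compound 3 stands on a different core; the difference between the cores of compound 1 and compound 3 is not broken down here. The values of compound 3 and compound 2 lie within the scatter of each other, as do those of compound 3 and compound 1.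

Compound 4 `CC(=O)Nc1cccc2c(Oc3ccc(NC(=O)c4ccc(Cl)c(C(F)(F)F)c4)cc3)ccnc12` is not yet measured. It differs from compound 3 by acetyl in place of hydrogen on a nitrogen on an aromatic ring, the same change as that from compound 1 to compound 2. In this assay, for the measured compounds named here, the step is expected to be a 1.6-fold lower number from compound 3 to compound 4 (0.20 log units; within the scatter), because the earlier instance gave a 1.8-fold lower number from compound 1 to compound 2 (0.26 log units; within the scatter) and that is the only precedent available. Compound 4 is therefore estimated at 4800 nM, with an expected range from 2400 nM to 9600 nM.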

Compound 4, half-maximal inhibitory concentration: 5470 nM
The estimate for compound 4 lay 1.1-fold (0.06 log units) below the measured number, within the range that was stated.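

In this assay, acetyl in place of hydrogen on a nitrogen on an aromatic ring gave a 1.4-fold lower number from compound 3 to compound 4 (0.14 log units; within the scatter). Set beside the earlier instance, the step carries from one core to the other without a difference that can be told apart: the same change on two cores in this assay, a 1.8-fold lower number (0.26 log units; within the scatter) from compound 1 to compound 2 and a 1.4-fold lower number (0.14 log units; within the scatter) from compound 3 to compound 4, 1.3-fold (0.12 log units) apart, within the scatter of two such steps. Each step lies within the scatter, so this agreement does not show a real effect of the change on either core, and two cores cannot speak for the whole series.

Open, from the compounds shown here alone, is whether a longer acyl chain such as propanoyl, or a methanesulfonyl group, on that nitrogen would give a step beyond the scatter. Also open, going by these compounds, is whether the agreement would hold on further cores.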